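Lengthening the chain of compound 3

The source may report more compounds than this note shows. Statements on the series, on what has been measured and on what is new or still open speak of the compounds shown alone.

- compound 1 `Cc1ccc(-c2cnc(N(Cc3ccc(C(=O)NO)cc3)CC(C)C)s2)cc1`: 7420 nM
- compound 2 `Cc1ccc(OCCCN(Cc2ccc(C(=O)NO)cc2)c2ncc(-c3ccc(C)cc3)s2)cc1`: 12200 nM
- compound 3 `CCCCN(Cc1ccc(C(=O)NO)cc1)c1ncc(-c2ccc(C)cc2)s1`: 4300 nM

These three compounds were measured in a functional assay on HepG2 cells (Homo sapiens) for antiproliferative activity, read by MTT assay, with a stated time of 48 h (on this read-out higher numbers stand for weaker inhibition of growth and lower numbers for stronger inhibition of growth), where a small gap between two numbers can be simple repeat scatter. Compound 3, at 4300 nM, cannot be told apart from compound 1, as the step is a 1.7-fold lower number from compound 1 to compound 3 (0.24 log units; within the scatter). It is clearly separated from compound 2, by a 2.8-fold lower number from compound 2 to compound 3 (0.45 log units; beyond the scatter).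

The next compound is compound 4 `CCCCCCN(Cc1ccc(C(=O)NO)cc1)c1ncc(-c2ccc(C)cc2)s1`. The change is ethyl in place of hydrogen on a saturated chain carbon, four bonds along the chain from a nitrogen on an aromatic ring, so the same difference reads ethyl to butyl when cut one bond further out.

For the measured compounds named here, two measured steps bear on this. Swapping the chain end of compound 2 for methyl gave a 2.8-fold lower number from compound 2 to compound 3 (0.45 log units; beyond the scatter), the only step beyond the scatter, but that swap removes far more than ethyl adds. Changing the branched chain gave only a 1.7-fold lower number from compound 1 to compound 3 (0.24 log units; within the scatter). A small step is therefore expected, with nothing beyond the scatter and at most a slight drift upward.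

The expected step is a 1.1-fold higher number from compound 3 to compound 4 (0.05 log units; within the scatter).

For compound 4 the estimate is 4800 nM, with an expected range of 2200 nM to 10000 nM.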

Compound 4, concentration for 50% growth inhibition: 7420 nM
Compound 4: the middle estimate sits 1.5-fold (0.19 log units) below what was measured; the measured number falls inside the stated range.
By their numbers in this assay, from the lowest: compounds 3, 1, 4 and 2 (each within the scatter of the next, the first and the last beyond it).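

In this assay, ethyl in place of hydrogen on a saturated chain carbon, four bonds along the chain from a nitrogen on an aromatic ring, gives a 1.7-fold higher number from compound 3 to compound 4 (0.24 log units; within the scatter), so at this place the added ethyl cannot be told apart from hydrogen. Compound 4 also cannot be told apart from the other two compounds: pentyl in place of isopropyl gives no change at the digits printed from compound 1 to compound 4 (within the scatter), and propyl in place of 4-methylphenoxy gives a 1.6-fold lower number from compound 2 to compound 4 (0.22 log units; within the scatter). Compound 3 stood clearly apart from compound 2 but compound 4 does not, so the only clear gap among these four compounds rests on that single pair, and this chain shows no firm trend with length.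

Still open, on these data alone, is whether a longer chain, or an amine or a carboxylic acid placed on this same chain, would give a step beyond the scatter in either direction. No supporting measurement is available that could explain why these numbers fall as they do.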